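This account rests on a few compounds, and the source may have more. Where it says the series, first, only, none or still open, it means among the compounds named here.

Measured compounds:
compound 1 `N#Cc1cnc(NCc2cnccc2C(F)(F)F)cc1N[C@H]1C[C@@H](O)C1`; in an assay on isolated protein for inhibition of protein kinase C theta type (Homo sapiens), read by TR-FRET, with a stated time of 2 h (a higher number here means a weaker inhibitor, a lower number a stronger inhibitor), compound 1 gives 500 nM.
compound 2 `N#Cc1cnc(NCc2cnccc2C(F)(F)F)cc1N[C@H]1CC[C@H](O)CC1`; in this assay compound 2 gives 350 nM.
compound 3 `CNC(=O)[C@H]1CC[C@@H](Nc2cc(NCc3cnccc3C(F)(F)F)ncc2C#N)CC1`; in this assay compound 3 gives 27 nM.

Compound 3 carries the lowest number of the three, separated from compound 2 by a 13-fold lower number from compound 2 to compound 3 (1.11 log units; beyond the scatter) and from compound 1 by a 19-fold lower number from compound 1 to compound 3 (1.27 log units; beyond the scatter). Compound 4 `CC1(C)C[C@@H](Nc2cc(NCc3cnccc3C(F)(F)F)ncc2C#N)CC[C@H]1O` differs from compound 3 by 4-hydroxy-3,3-dimethylcyclohexyl in place of 4-(methylcarbamoyl)cyclohexyl on a nitrogen on an aromatic ring. The step that bears most directly is a 13-fold lower number from compound 2 to compound 3 (1.11 log units; beyond the scatter), which the change in compound 4 largely reverses by bringing back a hydroxyl-bearing ring; a 1.4-fold lower number from compound 1 to compound 2 (0.15 log units; within the scatter) shows the two measured hydroxyl rings within the scatter of each other. Within the data shown here, the added methyl groups have no measured precedent. For compound 4 the expected step is a 9.3-fold higher number from compound 3 to compound 4 (0.97 log units; beyond the scatter), upward. In this assay compound 4 is estimated at 250 nM, range 80 nM to 800 nM.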

Compound 4, half-maximal inhibitory concentration: 120 nM
For compound 4 the middle estimate is 2.1-fold (0.32 log units) above the measured one, and the stated range covers the measured number.
By their numbers in this assay, from the lowest: compound 3; then compound 4; then compounds 2 and 1 (each within the scatter of the next).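

In this assay, 4-hydroxy-3,3-dimethylcyclohexyl on the nitrogen separates from the two other hydroxyl rings, with a 2.9-fold lower number from compound 2 to compound 4 (0.46 log units; beyond the scatter) and a 4.2-fold lower number from compound 1 to compound 4 (0.62 log units; beyond the scatter), so hydroxyl rings at this position no longer sit at one level. The 4-(methylcarbamoyl)cyclohexyl group still keeps its lead, with a 4.4-fold higher number from compound 3 to compound 4 (0.65 log units; beyond the scatter) on this change. Nothing measured here accounts for either shift.

Open, on these data alone, is whether a single methyl on the hydroxycyclohexyl ring would give the same gain. Also open, as far as these compounds go, is whether an amine or a carboxylic acid in place of the methylcarbamoyl group would hold the level of compound 3.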